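Chain-length changes on the acyl group in a melatonin series

The source may report more compounds than this note shows. Statements on the series, on what has been measured and on what is new or still open speak of the compounds shown alone.

Compound 1 `CCCC(=O)NCCCCc1ccccc1OC` gives 116 nM in an assay for binding affinity to melatonin receptor (Gallus gallus); on this read-out higher numbers stand for weaker inhibition and lower numbers for stronger inhibition. Compound 2 `CCCCC(=O)NCCCCc1ccccc1OC` gives 9190 nM in this assay, and the difference between the two, (methyl in place of hydrogen on a saturated chain carbon, three bonds along the chain from a carbonyl carbon), makes the step of a 79-fold higher number from compound 1 to compound 2 (1.90 log units; beyond the scatter). Compound 3 `CC(=O)NCCCc1cccc(F)c1` gives 1920 nM; the difference between its core and the core of compound 1 is not broken down here.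

Compound 4 `CCC(=O)NCCCc1cccc(F)c1` has not been measured. It differs from compound 3 by methyl in place of hydrogen on a saturated chain carbon bound to a carbonyl carbon. This is the same kind of change as that from compound 1 to compound 2, but the place is not the same: in compound 2 the methyl enters on a saturated chain carbon three bonds along the chain from a carbonyl carbon, whereas in compound 4 it enters on a saturated chain carbon bound to a carbonyl carbon. Among the measured compounds shown here, the single earlier step in this assay is large and unfavourable, but it sits at a different place on a different core, so it is not taken over directly. The step from compound 3 to compound 4 is expected to be about a 1.3-fold lower number from compound 3 to compound 4 (0.11 log units; within the scatter), with wide uncertainty. Compound 4 is estimated at 1500 nM, within 300 nM to 7000 nM.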

Compound 4, inhibition constant: 740 nM
Compound 4: middle estimate off by 2.0-fold (0.31 log units), on the high side, and the stated range covers the measured number.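

In this assay, acetyl to propanoyl gives a 2.6-fold lower number from compound 3 to compound 4 (0.41 log units; beyond the scatter), which runs opposite to the earlier step, and the two steps clearly differ: the same change on two cores in this assay, a 79-fold higher number (1.90 log units; beyond the scatter) from compound 1 to compound 2 and a 2.6-fold lower number (0.41 log units; beyond the scatter) from compound 3 to compound 4, 210-fold (2.31 log units) apart, beyond the scatter of two such steps. Among the compounds shown, neither the direction nor the size of a methyl in place of hydrogen on the acyl chain carries from one core to the other. This does not show whether the core or the place of the methyl sets the gap: the methyl enters on a saturated chain carbon bound to a carbonyl carbon in compound 4 and three bonds along the chain from a carbonyl carbon in compound 2, so both differences occur together.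

The compounds shown leave open how a butanoyl and a pentanoyl group behave on the core of compound 3, a pair that would hold the place fixed while the core changes. Also open, on these data alone, is how an acetyl and a propanoyl group behave on the core of compound 1.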